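This account rests on a few compounds, and the source may have more. Where it says the series, first, only, none or still open, it means among the compounds named here.

Within the data shown here, compound 1 `CCCCc1cn(C[C@H](O)[C@H]2OC(=O)C(OCc3ccccc3)=C2OCc2ccccc2)nn1` gives 26300 nM in an ADME assay on HFF cells (Homo sapiens) for cytotoxicity, read by MTT assay, with a stated time of 72 h (a lower number here means a stronger inhibitor, a higher number a weaker inhibitor), and that is the only plain number among the three values shown. Compound 3 `COc1ccc(-c2cn(C[C@H](O)[C@H]3OC(=O)C(OCc4ccccc4)=C3OCc3ccccc3)nn2)cc1` sits at a limit of the assay, < 10 nM in this assay. Compound 2 `COc1ccccc1-c1cn(C/C=C2\OC(=O)C(OCc3ccccc3)=C2OCc2ccccc2)nn1` likewise sits at a limit, > 100000 nM in this assay. Among the measured compounds shown here, the single measured step, an at least 2600-fold lower number from compound 1 to compound 3 (3.41 log units; beyond the scatter), is large, and its endpoint is the limit of < 10 nM in this assay, at which 1 of the 3 values shown sits. Compound 4 `O=C1O[C@H]([C@@H](O)Cn2cc(CCO)nn2)C(OCc2ccccc2)=C1OCc1ccccc1` differs from compound 1 by hydroxy in place of ethyl on a saturated chain carbon, two bonds along the chain from an aromatic carbon. For the measured compounds named here, that measured step alters a different group, so none of the measured steps bears directly on this change. The expectation is therefore a step no larger than the scatter, a 1.1-fold higher number from compound 1 to compound 4 (0.06 log units; within the scatter). For compound 4 in this assay the estimate is 30000 nM, with a range from 8000 nM to 100000 nM.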

Compound 4, half-maximal inhibitory concentration: 58500 nM
For compound 4 the middle estimate is 2.0-fold (0.29 log units) below the measured one; the measured number falls inside the stated range.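

In this assay, 2-hydroxyethyl in place of butyl shifts the number only modestly, giving a 2.2-fold higher number from compound 1 to compound 4 (0.35 log units; beyond the scatter), so a hydroxy group at this place on the chain leaves compound 4 close to compound 1 on the scale of this series. The 4-methoxyphenyl group matters far more, as 2-hydroxyethyl in its place gives an at least 5800-fold higher number from compound 3 to compound 4 (3.76 log units; beyond the scatter). That step starts from a limit for compound 3: the limit of < 10 nM in this assay, at which 1 of the 4 values shown sits.

The compounds shown leave open whether an amine or a carboxylic acid on this chain would move the number further. They also leave open whether a longer chain ending in hydroxy would stay near compound 4.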